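The source may report more compounds than this note shows. Statements on the series, on what has been measured and on what is new or still open speak of the compounds shown alone.

Measured so far in an assay on isolated protein for inhibition of glucose-6-phosphatase catalytic subunit 1 (Homo sapiens), tested at 100 uM; a lower number here means less inhibition, a higher number more inhibition at the concentration tested (going by the name of the read-out):
compound 1, `CCCCN(C)CCCOc1cccc(O)c1C(=O)CC`, giving 17.3%;
compound 2, `CCC(=O)c1c(O)cccc1OCCCN1CCCC1`, giving 13.6%.

Compound 2 and compound 1 differ only in the amine on the saturated chain, and the step of a number 3.7 percentage points lower from compound 1 to compound 2 (within the scatter) lies within the scatter, so on the numbers shown compound 2 cannot be told apart from compound 1, its only neighbour.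

Compound 3, `CCC(=O)c1c(O)cccc1OCCCN1CCCCC1`, has not yet been measured. It differs from compound 2 in one place: piperidin-1-yl in place of pyrrolidin-1-yl on a saturated chain carbon, three bonds along the chain from an oxygen on an aromatic ring.

For the measured compounds named here, the only measured step that bears on this change is the one from compound 1 to compound 2, which also exchanges one amine for another at the same place on the chain, and that step, a number 3.7 percentage points lower from compound 1 to compound 2 (within the scatter), was within the scatter. Enlarging the ring by one carbon at the same place is a change of similar kind, and nothing in the two measured compounds points to a direction. Compound 3 is therefore expected to give a reading close to that of compound 2, with the step of a number 0.4 percentage points higher from compound 2 to compound 3 (within the scatter) not expected to exceed the scatter. Compound 3 is estimated at 14%, in the range 4% to 26%.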

Compound 3, a percentage reported as inhibition, at one concentration (the size of the read-out at that concentration, not a potency): < 5%
Compound 3 was reported as a limit (the forecaster's own chance of this, stated with the estimate: 0%); middle value at least 9 percentage points away from the limit.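

In this assay compound 3 is reported only as a limit, < 5%, so any step to it gives a floor and not a measured size: the limit of < 5% in this assay, at which 1 of the 3 values shown sits. Putting piperidin-1-yl in place of pyrrolidin-1-yl gives a number at least 8.6 percentage points lower from compound 2 to compound 3 (that floor lies within the scatter), so even with one more ring carbon at this place on the chain, the two rings cannot be separated on the numbers shown. For the compounds shown here, putting piperidin-1-yl in place of butyl(methyl)amino gives a number at least 12.3 percentage points lower from compound 1 to compound 3 (beyond the scatter), and this is the first exchange of amines at this place that lies beyond the scatter, which shows that the reading does respond to the amine here, something the earlier exchange alone did not show.

The compounds shown leave open how far under the limit compound 3 actually lies, and therefore how large either step truly is. They also leave open whether a morpholin-4-yl or azepan-1-yl ring, an open-chain amine such as diethylamino, or a longer chain between the ring oxygen and the amine would read closer to the butyl(methyl)amino compound or to the piperidin-1-yl compound.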